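From a five-membered ring to azepan-1-yl

This account rests on a few compounds, and the source may have more. Where it says the series, first, only, none or still open, it means among the compounds named here.

In a functional assay on MCF7 cells (Homo sapiens) for antiproliferative activity, read by CellTiter-Glo, with a stated time of 5 days (a lower number here means a stronger inhibitor, a higher number a weaker inhibitor), compound 1 `CC1=C(c2cccc(O)c2)C(c2ccc(OC[C@@H](C)N3CCCC3)cc2)Oc2ccc(O)cc21` gives 0.2 nM, compound 2 `CC1=C(c2cccc(O)c2)[C@H](c2ccc(OC[C@H](C)N3CC[C@@H](C)C3)cc2)Oc2ccc(O)cc21` gives 0.1 nM, and compound 3 `CC1=C(c2cccc(O)c2)C(c2ccc(OC[C@H](C)N3CC[C@@H](C)C3)cc2)Oc2ccc(O)cc21` gives 0.2 nM. Compound 3 therefore stands level with compound 1 at the digits shown. The step of no change at the digits printed from compound 1 to compound 3 (within the scatter) exchanges one ring-bearing group for another and stays within the scatter. The step of a 2.0-fold higher number from compound 2 to compound 3 (0.30 log units; within the scatter) is also within the scatter, and the only difference behind it is the fact that one of compounds 2 and 3 is drawn with a defined configuration and the other without, at the place where they differ.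

Compound 4 `CC1=C(c2cccc(O)c2)C(c2ccc(OC[C@H](C)N3CCCCCC3)cc2)Oc2ccc(O)cc21` brings a new change: a group of 7 heavy atoms (6 carbon, 1 nitrogen; one seven-membered non-aromatic ring with 1 hetero atom) in place of a group of 6 heavy atoms (5 carbon, 1 nitrogen; one five-membered non-aromatic ring with 1 hetero atom), on a saturated chain carbon bound to two saturated chain carbons. The azepan-1-yl group enters on a saturated chain carbon bound to two saturated chain carbons. No seven-membered ring has been measured yet in this set, so the closest guide is the ring-group exchange in no change at the digits printed from compound 1 to compound 3 (within the scatter), and no step beyond the scatter is expected. The estimated step is no change at the digits printed from compound 3 to compound 4 (within the scatter). In this assay, the expected value for compound 4 is 0.2 nM, with an estimated range from 0.07 nM to 0.6 nM.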

Compound 4, half-maximal inhibitory concentration: 0.2 nM
Beside the measured number, compound 4's estimate shows no gap at the digits printed; measured number inside the range.
By their numbers in this assay, from the lowest: compounds 2, 1, 3 and 4 (each within the scatter of the next).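

In this assay, for the compounds shown here, the azepan-1-yl group shows that a seven-membered ring is tolerated on a saturated chain carbon bound to two saturated chain carbons, where the earlier compounds carried only five-membered rings (the result is no change at the digits printed from compound 3 to compound 4 (within the scatter)). The wider exchange, which replaces a larger part of the side chain, gives the same reading (no change at the digits printed from compound 1 to compound 4 (within the scatter)), so among these compounds, going from a five-membered to a seven-membered ring leaves the number level. Nothing measured here offers a reason for this flat result.

The compounds shown leave open whether a six-membered piperidin-1-yl ring, a morpholin-4-yl ring or an open-chain diethylamino group would also stay level. They also leave open how azepan-1-yl would read with the opposite configuration at the chain carbon that carries it.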